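A few compounds are considered here, and "the series" means these few. Any claim that something is new, unique, unknown or untested is made for them only; others in the source may bear on it.

Three compounds that share a core and differ in what hangs on it have been measured for cytotoxicity. Compound 1 `N#Cc1ccc(/C=C2\CN(S(=O)(=O)c3ccc(F)cc3)C/C(=C\c3ccc(C#N)cc3)C2=O)cc1` carries a 4-cyanophenyl on each side of the core, and in a functional assay on HepG2 cells (Homo sapiens) for cytotoxicity, read by MTT assay, with a stated time of 24 h (a higher number here means a weaker inhibitor, a lower number a stronger inhibitor), compound 1 gives 11500 nM. Compound 2 `COc1cc(/C=C2\CN(S(=O)(=O)c3ccc(F)cc3)C/C(=C\c3ccc(C#N)cc3)C2=O)cc(OC)c1OC` differs from it by one change, (3,4,5-trimethoxyphenyl in place of 4-cyanophenyl on a double-bonded chain carbon bound to a double-bonded ring carbon), and this brought a 2.3-fold lower number from compound 1 to compound 2 (0.37 log units; beyond the scatter). Compound 3 `CC(=O)Nc1ccc(S(=O)(=O)N2C/C(=C\c3ccc(C#N)cc3)C(=O)/C(=C/c3ccccc3F)C2)cc1` has a different core from compound 1; the difference between the two cores is not broken down here. In this assay compound 3 gives 4960 nM, and compound 2 gives 4950 nM, so the two lie within the usual scatter of each other and no order between them can be read.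

Compound 4 `COc1cc(/C=C2\CN(S(=O)(=O)c3ccc(NC(C)=O)cc3)C/C(=C\c3ccccc3F)C2=O)cc(OC)c1OC` is the unmeasured member of the set. It is related to compound 3 by 3,4,5-trimethoxyphenyl in place of 4-cyanophenyl on a double-bonded chain carbon bound to a double-bonded ring carbon, which is the same change as that from compound 1 to compound 2, at the same place, and it is the only change that appears twice among these four compounds. Because a 2.3-fold lower number from compound 1 to compound 2 (0.37 log units; beyond the scatter) was found once, the expected step from compound 3 to compound 4 in this assay is a 2.3-fold lower number from compound 3 to compound 4 (0.35 log units; beyond the scatter), a step of similar size, resting on a single precedent and therefore carrying a wide margin. On that basis compound 4 is expected to give about 2200 nM in this assay, with the likely range running from 900 nM to 5500 nM.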

Compound 4, half-maximal inhibitory concentration: 4750 nM
Compound 4: middle estimate off by 2.2-fold (0.33 log units), on the low side; the range from low to high includes it.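

On the core of compound 3, placing 3,4,5-trimethoxyphenyl where 4-cyanophenyl stood gave a 1.0-fold lower number from compound 3 to compound 4 (0.02 log units; within the scatter) in this assay, so the two numbers on this core cannot be told apart, whereas the same change on the core of compound 1 gave a step beyond the scatter. Set side by side, however, the two steps cannot be separated from each other: the same change on two cores in this assay, a 2.3-fold lower number (0.37 log units; beyond the scatter) from compound 1 to compound 2 and a 1.0-fold lower number (0.02 log units; within the scatter) from compound 3 to compound 4, 2.2-fold (0.35 log units) apart, within the scatter of two such steps This shows that the change has no established size when it is carried from one core to the other, and it does not show that the cores respond differently, nor that they respond alike, as each core offers only a single pair and the data give no cause for the gap between the two readings.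

The compounds shown leave open how the change would read on a third core, and whether more pairs on these two cores would bring the steps together or pull them apart. They also leave open what an amine or a carboxylic acid on the phenyl ring would do in this assay at the same place, on a double-bonded chain carbon bound to a double-bonded ring carbon.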